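A few compounds are considered here, and "the series" means these few. Any claim that something is new, unique, unknown or untested is made for them only; others in the source may bear on it.

Compound 1 `C=C(c1ccc(OC)cc1NC(=O)CNCC)c1ccc(OC)c2c1OC(C)(C)C=C2` gives 1090 nM in a functional assay on HeLa cells (Homo sapiens) for antiproliferative activity, read by MTT assay, with a stated time of 48 h; a lower number here means a stronger inhibitor, a higher number a weaker inhibitor.
Compound 2 `C=C(c1ccc2c(c1)C=CC(C)(C)O2)c1ccc(OC)cc1NC(=O)CNCC` gives 1580 nM in this assay.
Compound 3 `C=C(c1ccc(OC)cc1NC(=O)CN(C)C)c1ccc(OC)c2c1OC(C)(C)C=C2` gives 900 nM in this assay.

Compound 4 `C=C(c1ccc2c(c1)C=CC(C)(C)O2)c1ccc(OC)cc1NC(=O)CN(C)C` has not yet been measured in this assay. It differs from compound 2 by dimethylamino in place of ethylamino on a saturated chain carbon bound to a carbonyl carbon. The same change, at the same place, separates compound 1 from compound 3, where it reads dimethylamino in place of ethylamino on a saturated chain carbon bound to a carbonyl carbon and gives a step of a 1.2-fold lower number from compound 1 to compound 3 (0.08 log units; within the scatter). The difference between the core of compound 1 and the core of compound 2 is not broken down here. Going by the values given here, since the change is the same and the one measured step is within the scatter, compound 4 is expected to move from compound 2 by about a 1.2-fold lower number from compound 2 to compound 4 (0.08 log units; within the scatter), resting on a 1.2-fold lower number from compound 1 to compound 3 (0.08 log units; within the scatter). Compound 4 is therefore estimated at 1300 nM, with a likely range from 650 nM to 2600 nM.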

Compound 4, half-maximal inhibitory concentration: 640 nM
Estimate against measurement, compound 4: 2.0-fold (0.31 log units) above, and the stated range ends above it.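

In this assay, putting dimethylamino in place of ethylamino on the core of compound 2 gives a 2.5-fold lower number from compound 2 to compound 4 (0.39 log units; beyond the scatter), a modest step. Set beside the same change on the core of compound 1, this step does not differ from the earlier one by more than the scatter allows: the same change on two cores in this assay, a 1.2-fold lower number (0.08 log units; within the scatter) from compound 1 to compound 3 and a 2.5-fold lower number (0.39 log units; beyond the scatter) from compound 2 to compound 4, 2.0-fold (0.31 log units) apart, within the scatter of two such steps. The data therefore give no sign that the core alters the effect of this change, but one pair of steps cannot show that the effect is the same on both cores, or that it would hold on a third.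

The compounds shown leave open how other groups would read at this place, such as a primary amine, diethylamino or a pyrrolidine ring. They also leave open what a longer chain carrying the dimethylamino would give.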